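Cyclopropyl in place of ethyl on the amide carbonyl

The compounds below may be only part of what the source reports. "The series", "measured", "known", "first", "only" and "open" are said of these compounds alone.

Three compounds of this series have been measured in an assay on NIH3T3 cells with melatonin receptor type 1A (Homo sapiens) as the target; a lower number here means a stronger inhibitor, a higher number a weaker inhibitor:

Compound 1, `CNC(=O)NC[C@@H]1C[C@H]1c1cccc2c1OC(C(C)C)N2`: 11.8 nM
Compound 2, `CC(=O)NC[C@@H]1C[C@H]1c1cccc2nc(CCCCc3ccccc3)oc12`: 0.05 nM
Compound 3, `CCC(=O)NC[C@@H]1C[C@H]1c1cccc2nc(CCCCc3ccccc3)oc12`: 0.05 nM

Compound 3 stands level with compound 2 at the digits shown, and the two together give the lowest numbers of the three. The nearest neighbour of compound 3 is compound 2, and the step of no change at the digits printed from compound 2 to compound 3 (within the scatter) is within the scatter. The furthest is compound 1, whose number lies far above that of compound 3, beyond the scatter, and which also carries a different core.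

Compound 4, `O=C(NC[C@@H]1C[C@H]1c1cccc2nc(CCCCc3ccccc3)oc12)C1CC1`, differs from compound 3 by cyclopropyl in place of ethyl on a carbonyl carbon. Among the measured compounds shown here, the only measured step that bears on this change is no change at the digits printed from compound 2 to compound 3 (within the scatter), which also altered the group on the carbonyl carbon of the amide, and it produced nothing beyond the scatter. On that basis the step of a 1.2-fold higher number from compound 3 to compound 4 (0.08 log units; within the scatter) is expected to stay within the scatter as well, with no direction favoured. Compound 4 is therefore estimated at 0.06 nM in this assay, with a range from 0.02 nM to 0.2 nM.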

Compound 4, inhibition constant: 0.05 nM
Beside the measured number, compound 4's estimate is 1.2-fold (0.08 log units) above it; the range from low to high includes it.
By their numbers in this assay, from the lowest: compounds 2, 3 and 4 (each within the scatter of the next); then compound 1.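

In this assay, the group on the carbonyl carbon of the amide now runs from methyl through ethyl to cyclopropyl on the shared core, and both no change at the digits printed from compound 3 to compound 4 (within the scatter) and no change at the digits printed from compound 2 to compound 4 (within the scatter) stay within the scatter. The earlier compounds had shown only that a methyl could give way to an open ethyl chain, whereas this result shows that the same flat reading holds when a three-membered non-aromatic ring of carbon only enters at this place, so a ring here, at least of this size, does not move the number beyond the scatter. No measurement at hand accounts for this flat reading.

With only these three small groups on this core, the compounds shown do not reveal where the flat reading ends, and a longer chain such as butyl, a phenyl ring or a cyclohexyl ring on the carbonyl carbon could still behave differently. From the compounds shown here alone, it also stays open whether an amine on the carbonyl carbon, as in the methylamino group of compound 1, would keep the number level on this core, since compound 1 differs from the others in its core as well.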